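The source may report more compounds than this note shows. Statements on the series, on what has been measured and on what is new or still open speak of the compounds shown alone.

Measured compounds:
- compound 1, `N#CC1=C(N)OC(c2c[nH]c3ccccc23)=C(C#N)C1c1ccc(Br)cc1`: 22.7%
- compound 2, `Cc1ccccc1C1C(C#N)=C(N)OC(c2c[nH]c3ccccc23)=C1C#N`: 25.7%

Both were tested in a functional assay, tested at 400 ug/mL; a higher number here means a stronger effect of the compound at the concentration tested, a lower number a weaker effect. Among the measured compounds shown here, compound 1 has the lower of the two numbers, but its only neighbour, compound 2, sits just a number 3 percentage points higher from compound 1 to compound 2 (within the scatter), so the two cannot be told apart on these data.

Compound 3, `N#CC1=C(N)OC(c2c[nH]c3ccccc23)=C(C#N)C1c1ccc(F)cc1`, is not yet measured. It differs from compound 1 by fluoro in place of bromo on an aromatic carbon. For the measured compounds named here, no measured step speaks to this exact change. Going by the values given here, the one step known, a number 3 percentage points higher from compound 1 to compound 2 (within the scatter), swaps the whole group on the saturated ring carbon and still stays within the scatter, which gives no reason to expect a large effect from a smaller change at the same group.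

For compound 3 the expected step is therefore a number 0.7 percentage points lower from compound 1 to compound 3 (within the scatter), none beyond the scatter. The estimate for compound 3 in this assay is 22%, within a range from 8% to 38%.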

Compound 3, a percentage reported as activity, at one concentration (the size of the read-out at that concentration, not a potency): 26.7%
Compound 3: the middle estimate sits 4.7 percentage points below what was measured; the range from low to high includes it.
By their numbers in this assay, from the lowest: compounds 1, 2 and 3 (each within the scatter of the next).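

With everything else held fixed, fluoro in place of bromo on the aromatic carbon gives a number 4 percentage points higher from compound 1 to compound 3 (within the scatter) in this assay, so exchanging one halogen for the other at this place produces no readable change. The comparison of the whole groups on the saturated ring carbon gives a number 1 percentage points higher from compound 2 to compound 3 (within the scatter), so 4-fluorophenyl and 2-methylphenyl cannot be told apart here either, and the three groups shown all fall within the scatter of their neighbours in this assay. Nothing available offers an explanation for these results.

Going by these compounds, all three compounds carry a substituted phenyl on the saturated ring carbon, so it remains open whether an amine or a carboxylic acid on that phenyl, or a longer alkyl chain in its place, would move the read-out beyond the scatter. On these data alone, each number also comes from a single concentration, so how the compounds would compare across other concentrations is unknown.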